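Swapping the Amide Tail on a Potassium Channel Ligand

The compounds below may be only part of what the source reports. "The series", "measured", "known", "first", "only" and "open" are said of these compounds alone.

Compound 1 `CC(C)=CC(=O)Nc1c(C(O)(C(F)(F)F)C(F)(F)F)ccc2ccccc12`: 46 nM
Compound 2 `O=C(CC1CCCC1)Nc1c(C(O)(C(F)(F)F)C(F)(F)F)ccc2ccccc12`: 81 nM

In an assay on LtK cells with ATP-sensitive inward rectifier potassium channel 11 (Homo sapiens) as the target (on this read-out lower numbers stand for an effect already at smaller amounts and higher numbers for an effect only at larger amounts of compound), compound 1 gives 46 nM and compound 2 gives 81 nM. Compound 2 and compound 1 cannot be told apart, since the step of a 1.8-fold higher number from compound 1 to compound 2 (0.25 log units; within the scatter) lies within the scatter. Compound 3 `Cc1ccccc1C(=O)Nc1c(C(O)(C(F)(F)F)C(F)(F)F)ccc2ccccc12` differs from compound 2 by 2-methylphenyl in place of cyclopentylmethyl on a carbonyl carbon. Among the measured compounds shown here, the only measured step at this carbonyl carbon, a 1.8-fold higher number from compound 1 to compound 2 (0.25 log units; within the scatter), stayed within the scatter, so the new group is expected to bring no step beyond the scatter either: a 1.2-fold lower number from compound 2 to compound 3 (0.06 log units; within the scatter). Compound 3 is therefore estimated at 70 nM, with a range from 25 nM to 200 nM.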

Compound 3, half-maximal effective concentration: 5550 nM
Beside the measured number, compound 3's estimate is 79-fold (1.90 log units) below it; measured number above the stated range.
By their numbers in this assay, from the lowest: compounds 1 and 2 (each within the scatter of the next); then compound 3.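

This carbonyl carbon turns out not to accept every group. In this assay, 2-methylphenyl here brings a 69-fold higher number from compound 2 to compound 3 (1.84 log units; beyond the scatter) and also a 120-fold higher number from compound 1 to compound 3 (2.08 log units; beyond the scatter). The tolerance seen with 2-methylprop-1-en-1-yl and cyclopentylmethyl therefore does not extend to this aromatic ring, and no measurement shown here explains the jump.

As far as these compounds go, it remains open whether the ring itself or its methyl group accounts for the jump, a question that plain phenyl on the same carbonyl carbon would address. A cyclohexyl group would show whether a six-membered ring without aromatic character behaves like cyclopentylmethyl.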